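Removing a Methyl from the Aniline Ring of Compound 2

The source may hold more compounds than are shown below. What is called first, only, known or untested is meant among the compounds shown, and "the series" means these compounds.

Compound 1, `COc1ccc(C(=O)/C=C\Nc2ccc(-c3nc4cc(OC)c(OC)c(OC)c4s3)cc2C)cc1O`, gives 12400 nM in a functional assay on MDA-MB-231 cells (Homo sapiens) for antiproliferative activity, read by sulforhodamine B assay, with a stated time of 48 h; on this read-out higher numbers stand for weaker inhibition and lower numbers for stronger inhibition.
Compound 2, `COc1ccc2nc(-c3ccc(N/C=C\C(=O)c4ccc(OC)c(O)c4)c(C)c3)sc2c1`, gives 14000 nM in this assay.
Compound 3, `COc1ccc(C(=O)/C=C\Nc2ccc(-c3nc4cc(OC)c(OC)c(OC)c4s3)cc2)cc1O`, gives 18100 nM in this assay.

Compound 1 and compound 3 share one core and differ in a single spot: hydrogen in place of methyl on an aromatic carbon. The step this makes is a 1.5-fold higher number from compound 1 to compound 3 (0.16 log units; within the scatter). The three measured values all lie close together, and none of the steps among them reaches beyond the usual scatter of repeated measurements.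

Compound 2 carries a different core from compound 1; the difference between the two cores is not broken down here. Compound 4, `COc1ccc2nc(-c3ccc(N/C=C\C(=O)c4ccc(OC)c(O)c4)cc3)sc2c1`, is the unmeasured partner of compound 2 and differs from it by hydrogen in place of methyl on an aromatic carbon. This is the same change already seen between compound 1 and compound 3, made on the same kind of position.

Since the earlier step was a 1.5-fold higher number from compound 1 to compound 3 (0.16 log units; within the scatter), a step of similar size is expected here, a 1.4-fold higher number from compound 2 to compound 4 (0.15 log units; within the scatter). On that basis compound 4 is estimated to give about 20000 nM in this assay, with a plausible range from 9000 nM to 45000 nM.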

Compound 4, half-maximal inhibitory concentration: 18900 nM
Estimate against measurement, compound 4: 1.1-fold (0.02 log units) above, and the stated range covers the measured number.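

In this assay, putting hydrogen in place of the methyl on the aromatic carbon gives a 1.4-fold higher number from compound 2 to compound 4 (0.13 log units; within the scatter). In this small set, the same change looks alike on the two cores, with no difference between the two steps that can be told apart from ordinary measurement variation: the same change on two cores in this assay, a 1.5-fold higher number (0.16 log units; within the scatter) from compound 1 to compound 3 and a 1.4-fold higher number (0.13 log units; within the scatter) from compound 2 to compound 4, 1.1-fold (0.03 log units) apart, within the scatter of two such steps. Among these compounds, both steps lie within the usual scatter of repeated measurements, however, so the agreement shows only that this change leaves the number about where it was on these two cores; it does not show that the methyl improves inhibition, and two cores are too few to set a rule for the whole series.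

The compounds shown leave open whether a different group on that same aromatic carbon, such as an ethyl group, a chlorine atom or an amine, would shift the number beyond the scatter. They also leave open whether the swap of methyl for hydrogen would behave the same way on a third core.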